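A few compounds are considered here, and "the series" means these few. Any claim that something is new, unique, unknown or untested is made for them only; others in the source may bear on it.

Compound 1 `CCCCNc1cccc(NC(=O)c2ccc(OCCC)cc2)n1`: 77800 nM
Compound 2 `CCCCCNc1cccc(NC(=O)c2ccc(OCCC)cc2)n1`: > 100000 nM, a limit
Compound 3 `CCCOc1ccc(C(=O)Nc2cccc(Nc3ccccc3F)n2)cc1`: > 100000 nM, a limit

In an in vitro assay on HEK-tsA201 cells for antagonist activity at Neuronal acetylcholine receptor; alpha3/beta4 (Homo sapiens), read by fluorescence and calcium flux (on this read-out higher numbers stand for weaker inhibition and lower numbers for stronger inhibition), compound 3 is reported only as a limit, > 100000 nM, with no number behind it. The same holds for compound 2, as noted in the limit of > 100000 nM in this assay, at which 2 of the 3 values shown sit. Compound 1 gives 77800 nM. The measured steps are an at least 1.2-fold higher number from compound 1 to compound 3 (0.10 log units; that floor lies within the scatter) and an at least 1.2-fold higher number from compound 1 to compound 2 (0.10 log units; that floor lies within the scatter), each only a floor lying within the scatter, while a step that the two limits leave unreadable from compound 2 to compound 3. Compound 4 `CCCOc1ccc(C(=O)Nc2cccc(N3CCCCC3)n2)cc1` carries piperidin-1-yl in place of (2-fluorophenyl)amino on an aromatic carbon. For the measured compounds named here, none of the measured steps exchanges a substituted amine for a ring closed onto the nitrogen, so none bears directly on this change, and with all three measured compounds weak or at the limit, no shift beyond the scatter is expected. Compound 4 is therefore expected near 100000 nM, between 30000 nM and 300000 nM, which means an expected step of a number no higher from compound 3 to compound 4 (the limit leaves the size open). A limit rather than a number is expected as the most likely outcome for compound 4.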

Compound 4, half-maximal inhibitory concentration: > 100000 nM
Compound 4 gave a limit, no number; the forecaster's own chance of this, stated with the estimate: 70%; the middle value sits exactly at the limit.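

In this assay compound 4 stands as a limit, > 100000 nM, so piperidin-1-yl, which has no hydrogen-bond donor, yields no number at this position next to the ring nitrogen. Against butylamino, the only reading is an at least 1.2-fold higher number from compound 1 to compound 4 (0.10 log units; that floor lies within the scatter). The steps to compound 4 from compound 2 and compound 3 cannot be read, and this position now stacks up at one ceiling: the limit of > 100000 nM in this assay, at which 3 of the 4 values shown sit.

On these data alone, only compound 1 carries a number, so what governs inhibition at this position stays open. As far as these compounds go, how a shorter chain such as propylamino, a free amine or a morpholine ring would read here also stays open.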